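From Bromo to Methoxy: Expecting Little Change

The compounds below may be only part of what the source reports. "The series", "measured", "known", "first", "only" and "open" are said of these compounds alone.

Compound 1 `Nc1ccccc1NC(=O)c1ccc(CSc2ccc(Br)cc2)cc1` was tested in a functional assay on A549 cells (Homo sapiens) for inhibition, read by CCK-8 assay, with a stated time of 72 h, tested at 2 uM (on this read-out higher numbers stand for more inhibition of growth at the one concentration tested and lower numbers for less inhibition of growth), where compound 1 gives 33.2%. Compound 2 `Nc1ccccc1NC(=O)c1ccc(CSc2ccc(C(F)(F)F)cn2)cc1` was measured in the same way; in this assay compound 2 gives 37.1%. Within the data shown here, of the two numbers known, compound 1 stands lowest, but the gap to compound 2 lies within the scatter, so the two compounds cannot be told apart on this read-out.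

Compound 3 `COc1ccc(SCc2ccc(C(=O)Nc3ccccc3N)cc2)cc1` has not yet been measured. It differs from compound 1 in one place: methoxy in place of bromo on an aromatic carbon. The bromo leaves and a methoxy enters on an aromatic carbon of a six-membered aromatic ring of carbon only, para to a large group.

Among the measured compounds shown here, no step between measured compounds is known, so there is nothing to show how a change of this kind moves the read-out. The two measured values sit close together, and with nothing more to go on, the step from compound 1 to compound 3 is expected to be small, a number 1.2 percentage points lower from compound 1 to compound 3 (within the scatter), in no set direction beyond the scatter. Compound 3 is therefore estimated to give 32% in this assay, with a range from 15% to 50%.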

Compound 3, percent growth inhibition at one concentration: 45.7%
The estimate for compound 3 lay 13.7 percentage points below the measured number; the range from low to high includes it.
By their numbers in this assay, from the lowest: compounds 1, 2 and 3 (each within the scatter of the next, the first and the last beyond it).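

Swapping bromo for methoxy on this aromatic carbon, para to a large group, gives a number 12.5 percentage points higher from compound 1 to compound 3 (beyond the scatter) in this assay. This is the only step shown between compounds that differ in one place, and it establishes that a change at this single position, from 4-bromophenyl to 4-methoxyphenyl, can move growth inhibition by more than the usual scatter while the rest of the molecule stays the same. No measurement shown here explains why the read-out moves, and a single pair cannot separate the loss of bromo from the arrival of methoxy.

On these data alone, it remains open whether another group on the same carbon, such as a hydroxy, an amine, an ethoxy or a carboxylic acid, would raise the number further, leave it in place or bring it back down. One step also cannot show whether methoxy in place of bromo would act in the same way on another core, or how the two compounds would compare across a range of concentrations rather than at the one concentration tested.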